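Replacing the Acetyl with a Benzyl on the Aniline Nitrogen

The compounds below may be only part of what the source reports. "The series", "measured", "known", "first", "only" and "open" are said of these compounds alone.

Measured compounds and their values:
compound 1 `Cc1ccc(-c2c(C)c(-c3ccc4c(c3C)CCCO4)c(C(OC(C)(C)C)C(=O)O)c(C)c2NS(C)(=O)=O)cc1C` — 24000 nM
compound 2 `Cc1ccc(-c2c(C)c(-c3ccc(C)c(C)c3)c(C(OC(C)(C)C)C(=O)O)c(C)c2NC(=O)c2ccccc2)cc1C` — 9100 nM
compound 3 `CC(=O)Nc1c(C)c(C(OC(C)(C)C)C(=O)O)c(-c2ccc(C)c(C)c2)c(C)c1-c1ccc(C)c(C)c1` — 19000 nM

In an ADME assay on MT4 cells (Homo sapiens) for cytotoxicity, read by MTT assay, with a stated time of 4 days (on this read-out lower numbers stand for higher toxicity in this test and higher numbers for lower toxicity in this test), compound 3 gives 19000 nM, the second highest of the three numbers; compound 1 gives 24000 nM, which lies within the scatter of compound 3, while the number for compound 2 is lower, a 2.1-fold higher number from compound 2 to compound 3 (0.32 log units; beyond the scatter).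

Compound 4 `Cc1ccc(-c2c(C)c(-c3ccc(C)c(C)c3)c(C(OC(C)(C)C)C(=O)O)c(C)c2NCc2ccccc2)cc1C` has not yet been measured. It differs from compound 3 in one place: benzyl in place of acetyl on a nitrogen on an aromatic ring. Within the data shown here, the only measured step that touches the same nitrogen is the one from compound 2 to compound 3, where a benzoyl gave way to an acetyl and the number rose modestly, a 2.1-fold higher number from compound 2 to compound 3 (0.32 log units; beyond the scatter). Compound 4 brings the aromatic ring back, though without the carbonyl, so a step in the opposite direction, of roughly that size, is expected for compound 4 in this assay, namely a 1.9-fold lower number from compound 3 to compound 4 (0.28 log units; within the scatter). The estimate for compound 4 is therefore 10000 nM, with a range from 4000 nM to 25000 nM.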

Compound 4, half-maximal cytotoxic concentration: 4000 nM
Compound 4: the middle estimate sits 2.5-fold (0.40 log units) above what was measured; the range from low to high includes it.
By their numbers in this assay, from the lowest: compound 4; then compound 2; then compounds 3 and 1 (each within the scatter of the next).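

In this assay, the change seen is a 4.8-fold lower number from compound 3 to compound 4 (0.68 log units; beyond the scatter), so benzyl in place of acetyl on this nitrogen moves the number towards higher toxicity in this test. Compounds 2 and 3 both keep a carbonyl on this nitrogen, whereas compound 4 has none, and with the aromatic ring kept the number still falls, giving a 2.3-fold lower number from compound 2 to compound 4 (0.36 log units; beyond the scatter). Removing the carbonyl thus goes along with a lower number even when the ring stays, and nothing available here accounts for this.

A simple ethyl group or an unsubstituted amine on this nitrogen would show whether a lower number follows the loss of the carbonyl without any ring present. Going by these compounds, whether a longer chain between the nitrogen and the phenyl ring shifts the number further also remains open.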